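Adding a Methoxy Group to a Growth Inhibitor

The compounds below may be only part of what the source reports. "The series", "measured", "known", "first", "only" and "open" are said of these compounds alone.

Of the compounds shown here, three have so far been tested in a functional assay on U-87MG ATCC cells for antiproliferative activity against U-87 MG (Homo sapiens), read by MTT assay, with a stated time of 48 h, tested at 5 uM; on this read-out lower numbers stand for a stronger effect and higher numbers for a weaker effect at the one concentration tested. Compound 1 `COc1ccc(-c2nc(SCC(=O)c3sc(-c4ccccc4)nc3C)[nH]c(=O)c2C#N)cc1` gives 97.3%, and compound 3 `Cc1nc(-c2ccccc2)sc1C(=O)CSc1nc(-c2ccccc2)c(C#N)c(=O)[nH]1` gives 92.1%; they differ only by a (methoxy in place of hydrogen on an aromatic carbon), and the step of a number 5.2 percentage points higher from compound 3 to compound 1 (within the scatter) is small. Compound 2 `COc1ccc(-c2nc(C)c(C(=O)CSc3nc(N)c(C#N)c(-c4ccccc4)n3)s2)cc1` gives 61.8%, the lowest of the three and beyond the scatter from both others; the difference between its core and that of compound 3 is not broken down here. Compound 4 `COc1ccc(-c2nc(C)c(C(=O)CSc3nc(N)c(C#N)c(-c4ccc(OC)cc4)n3)s2)cc1` has not yet been measured. It carries the same change from compound 2, a (methoxy in place of hydrogen on an aromatic carbon), as compound 1 carries from compound 3. Because the earlier step of a number 5.2 percentage points higher from compound 3 to compound 1 (within the scatter) stayed within the scatter, a similarly small step is expected, a number 4.2 percentage points higher from compound 2 to compound 4 (within the scatter). Compound 4 is therefore estimated at 66%, likely between 52% and 80%.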

Compound 4, a percentage reported as activity, at one concentration (the size of the read-out at that concentration, not a potency): 35.6%
Estimate against measurement, compound 4: 30.4 percentage points above; measured number outside the range, below it.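

In this assay the change from phenyl to 4-methoxyphenyl gives a number 26.2 percentage points lower from compound 2 to compound 4 (beyond the scatter), so on this core the methoxy group goes with a stronger effect at the one concentration tested. Going by these compounds alone, with only two pairs, this sets no rule for the series, and it does not show which of the differences between the two cores is responsible or why. What it does show is that the step seen on one core cannot simply be carried over to the other: the same change on two cores in this assay, a number 5.2 percentage points higher (within the scatter) from compound 3 to compound 1 and a number 26.2 percentage points lower (beyond the scatter) from compound 2 to compound 4, 31.4 percentage points apart, beyond the scatter of two such steps

On these data alone, it remains open whether this gain is specific to methoxy or would also appear with another group in the same place on the core of compound 2, such as ethoxy, hydroxyl or fluorine. A single concentration also leaves open how the effects of compound 2 and compound 4 compare at other concentrations.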